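This account rests on a few compounds, and the source may have more. Where it says the series, first, only, none or still open, it means among the compounds named here.

Working notes on a small set of compounds tested in a functional assay on HeLa cells (Homo sapiens) for cytotoxicity, read by MTT assay, with a stated time of 48 h; a lower number here means a stronger inhibitor, a higher number a weaker inhibitor. Compound 1 `CCOC(=O)[C@]1(C(=O)Nc2ccccc2Cl)C[C@H]1c1cc(OC)c(OC)c(OC)c1` gives 42400 nM in this assay. Compound 2 `COc1cc([C@@H]2C[C@]2(CO)C(=O)NCc2ccc(C)cc2)cc(OC)c1OC` gives 17400 nM in this assay. Compound 3 `COc1cc([C@@H]2C[C@@]2(CO)C(=O)Nc2ccccc2Cl)cc(OC)c1OC` gives 13300 nM in this assay, the lowest of the three numbers; its nearest neighbour is compound 2, whose number lies within the scatter of that of compound 3, so no order can be read between these two, while compound 1 sits beyond the scatter with the higher number. For the measured compounds named here, no pair among the three measured compounds differs in a single place, so no step can be read from them.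

Compound 4 `COc1cc([C@@H]2C[C@]2(CO)C(=O)Nc2ccccc2Cl)cc(OC)c1OC` is the next compound and has not yet been measured. Relative to compound 3: the two compounds have the same atoms and bonds and differ only in configuration as drawn: 1 of 2 stereo elements differ; a stereocentre at a saturated ring carbon is drawn R in compound 3 and S in compound 4. Going by the values given here, nothing among the measured compounds shows what such a change in configuration does in this assay; the only guide is that all three measured numbers fall within a fairly narrow span. A step of modest size, in either direction, is expected rather than a large one. Compound 4 is expected to give about 20000 nM in this assay, with a likely range from 6000 nM to 70000 nM. The step from compound 3 to compound 4 is thus estimated as a 1.5-fold higher number from compound 3 to compound 4 (0.18 log units; within the scatter).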

Compound 4, half-maximal inhibitory concentration: 8100 nM
For compound 4 the middle estimate is 2.5-fold (0.39 log units) above the measured one, and the stated range covers the measured number.
By their numbers in this assay, from the lowest: compounds 4, 3 and 2 (each within the scatter of the next, the first and the last beyond it); then compound 1.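

The step of a 1.6-fold lower number from compound 3 to compound 4 (0.22 log units; within the scatter) is the first reading of configuration at this saturated ring carbon, and in this assay it allows no order to be read between the two drawn forms: the fact that compounds 3 and 4 differ only in the configuration as drawn

With compound 4 in hand, two further changes can each be read in one place: 2-chlorophenyl in place of 4-methylbenzyl on an amide-type nitrogen gives a 2.1-fold lower number from compound 2 to compound 4 (0.33 log units; beyond the scatter), and hydroxymethyl in place of ethoxycarbonyl on a saturated ring carbon gives a 5.2-fold lower number from compound 1 to compound 4 (0.72 log units; beyond the scatter). Both steps are modest but lie beyond the scatter, so the amide-nitrogen substituent and the ring-carbon substituent each register in this assay, whereas the configurational change does not separate from the scatter.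

On these data alone, it remains open what the second stereo element contributes, and whether the configurational step would look the same with 4-methylbenzyl on the amide-type nitrogen. As far as these compounds go, it is also open how a carboxylic acid or an aminomethyl group on that saturated ring carbon would compare with hydroxymethyl.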